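Removing a methyl from the aromatic nitrogen of a potent chalcone

The source may hold more compounds than are shown below. What is called first, only, known or untested is meant among the compounds shown, and "the series" means these compounds.

Of the compounds shown here, three have been tested so far, and a fourth waits for its number. Compound 1 `COc1ccc2c(/C=C/C(=O)c3cc(N)c(OC)c(OC)c3)c[nH]c2c1` and compound 2 `COc1ccc2c(/C=C/C(=O)c3cc(N)c(OC)c(OC)c3)cn(C)c2c1` share one core; compound 3 `COc1ccc2c(/C=C(\C)C(=O)c3cc(OC)c(OC)c([Se]C)c3)cn(C)c2c1` carries a different core, and the difference between the two cores is not broken down here. In a functional assay on MHCC97H cells (Homo sapiens) for antiproliferative activity, read by MTT assay, with a stated time of 48 h (a higher number here means a weaker inhibitor, a lower number a stronger inhibitor), compound 1 gives 186 nM and compound 2 gives 198 nM. Compound 3 gives 15 nM in this assay, the lowest number of the three.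

Compounds 2 and 1 differ in only one place: hydrogen in place of methyl on an aromatic nitrogen. That change made a 1.1-fold lower number from compound 2 to compound 1 (0.03 log units; within the scatter), so the two numbers sit together.

Compound 4 `COc1ccc2c(/C=C(\C)C(=O)c3cc(OC)c(OC)c([Se]C)c3)c[nH]c2c1` is compound 3 with exactly the same change: hydrogen in place of methyl on an aromatic nitrogen. Among the measured compounds shown here, both changes sit on the same kind of position, described in the same words, so the earlier pair is the only direct guide. Because a 1.1-fold lower number from compound 2 to compound 1 (0.03 log units; within the scatter) was within the scatter of repeated measurements, the expectation for compound 4 rests on that single pair and on the number for compound 3. The estimated step is a 1.1-fold lower number from compound 3 to compound 4 (0.03 log units; within the scatter), that is, essentially no movement. Compound 4 is therefore expected to give about 14 nM in this assay, with a likely range from 7 nM to 30 nM. One pair is a thin basis, and a different core may respond differently, so the range is kept wide.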

Compound 4, half-maximal inhibitory concentration: 6 nM
Compound 4: middle estimate off by 2.3-fold (0.37 log units), on the high side, and the stated range ends above it.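

On the core of compound 3, hydrogen in place of methyl on the aromatic nitrogen gave a 2.5-fold lower number from compound 3 to compound 4 (0.40 log units; beyond the scatter) in this assay, a modest step towards a stronger inhibitor. Set beside the earlier pair, this step cannot be told apart from the first one once the ordinary spread of repeated measurements is allowed for: the same change on two cores in this assay, a 1.1-fold lower number (0.03 log units; within the scatter) from compound 2 to compound 1 and a 2.5-fold lower number (0.40 log units; beyond the scatter) from compound 3 to compound 4, 2.3-fold (0.37 log units) apart, within the scatter of two such steps. The two pairs therefore show that this change can be carried from one core to the other without losing activity, and they give no sign that the cores respond differently, but they do not prove that the cores respond alike, and two pairs say nothing about any further core in the series.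

The compounds shown carry only a hydrogen or a methyl on that nitrogen, so it remains open how an ethyl group, a longer chain or a chain ending in an amine or a carboxylic acid would behave there. The two cores also differ from each other in more than one place, so these compounds leave open which of those differences matters for activity in this cell assay.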